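Chloro to Fluoro on the Shared Core

The source may hold more compounds than are shown below. What is called first, only, known or untested is meant among the compounds shown, and "the series" means these compounds.

In an assay on isolated protein for inhibition of Amine oxidase [flavin-containing] A (Homo sapiens), read by fluorescence, with a stated time of 15 min (a lower number here means a stronger inhibitor, a higher number a weaker inhibitor), compound 3 `COc1ccc(/C=C/c2cc(OC)cc(OC)c2/C=C/C(=O)c2cc3ccc(Cl)cc3oc2=O)cc1` reaches only the limit of the assay, > 60000 nM. Compound 1 `COc1ccc(/C=C/c2cc(OC)cc(OC)c2/C=C/C(=O)c2cc3cc(OC)ccc3oc2=O)cc1` also returns only a limit in this assay, > 60000 nM. For the measured compounds named here, compound 2 `COc1ccc(/C=C/c2cc(OC)cc(OC)c2/C=C/C(=O)c2cc3ccc(Br)cc3oc2=O)cc1` is the single member with a number in this assay, 3010 nM. Going by the values given here, the one measured step that bears on the present change is an at least 19-fold higher number from compound 2 to compound 3 (1.29 log units; beyond the scatter); its true size is open because of the limit of > 60000 nM in this assay, at which 2 of the 3 values shown sit, so only its direction and its lower bound are known.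

Compound 4 `COc1ccc(/C=C/c2cc(OC)cc(OC)c2/C=C/C(=O)c2cc3cc(F)ccc3oc2=O)cc1` differs from compound 3 by a group of 12 heavy atoms (9 carbon, 2 oxygen, 1 fluorine; one six-membered aromatic ring of carbon only, one six-membered aromatic ring with 1 hetero atom) in place of a group of 12 heavy atoms (9 carbon, 2 oxygen, 1 chlorine; one six-membered aromatic ring of carbon only, one six-membered aromatic ring with 1 hetero atom), on a carbonyl carbon. The exchange stays within the halogen series at the same place on the shared core, and the earlier halogen exchange from compound 2 carried the series from a number to the limit. With nothing to point the other way, compound 4 is expected to remain at or near the limit, so the expected step in this assay is a number no higher from compound 3 to compound 4 (the limit leaves the size open), a step of no consequence. The estimate for compound 4 in this assay is 60000 nM, within 15000 nM to 250000 nM.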

Compound 4, half-maximal inhibitory concentration: 44300 nM
Compound 4: the middle estimate sits 1.4-fold (0.13 log units) above what was measured; the range from low to high includes it.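

In this assay compound 4 returns a number rather than a limit, which gives the fluoro member a place on the scale that compound 1 and compound 3 could not take. The measured step of a 15-fold higher number from compound 2 to compound 4 (1.17 log units; beyond the scatter) shows that the fluoro group in this exchange does not match the bromo group of compound 2, and the gap is beyond the scatter. The remaining two steps, an at least 1.3-fold lower number from compound 3 to compound 4 (0.13 log units; that floor lies within the scatter) and an at least 1.3-fold lower number from compound 1 to compound 4 (0.13 log units; that floor lies within the scatter), give only floors within the scatter, so neither establishes a real gain for compound 4, and their true sizes stay unread: the limit of > 60000 nM in this assay, at which 2 of the 4 values shown sit.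

On these data alone, how far compound 1 and compound 3 truly lie from compound 4 remains open. Also open, as far as these compounds go, is how an amine or a carboxylic acid would read in place of the fluoro group.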